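Chloro removal in the series: expected effect on cytotoxicity

A few compounds are considered here, and "the series" means these few. Any claim that something is new, unique, unknown or untested is made for them only; others in the source may bear on it.

Compound 1 `O=C(/C=C/c1cccc([N+](=O)[O-])c1)c1ccc2ccccc2c1`: 20000 nM
Compound 2 `O=C(/C=C/c1cccc(Cl)c1)c1ccc2ccccc2c1`: 30000 nM

In a functional assay on L1210 cells (Mus musculus) for cytotoxicity, read by MTT assay, with a stated time of 24 h, in the presence of a further agent that is not named here (on this read-out higher numbers stand for weaker inhibition and lower numbers for stronger inhibition), compound 2 gives 30000 nM, which lies within the scatter of compound 1 at 20000 nM. Going by the values given here, with only this pair measured, compound 2 holds no distinct place on the numbers.

Next in the series is compound 3 `O=C(/C=C/c1ccccc1)c1ccc2ccccc2c1`, which differs from compound 2 at a single place: hydrogen in place of chloro on an aromatic carbon. This is hydrogen in place of chloro on an aromatic carbon, or 3-chlorophenyl to phenyl.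

Among the compounds with values here, one measured step bears on it: a 1.5-fold higher number from compound 1 to compound 2 (0.18 log units; within the scatter), with chloro in place of nitro on an aromatic carbon. Within the data shown here, no measured compound yet carries hydrogen at this carbon, so the data do not show the size of a step to the bare phenyl. The step between compound 1 and compound 2 offers only weak guidance, and no step beyond the scatter is expected in this assay, in either direction.

The expected step is a 1.2-fold lower number from compound 2 to compound 3 (0.08 log units; within the scatter). For compound 3 the estimated value is 25000 nM, with an expected range from 10000 nM to 60000 nM.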

Compound 3, half-maximal inhibitory concentration: 31000 nM
For compound 3 the middle estimate is 1.2-fold (0.09 log units) below the measured one; the measured number falls inside the stated range.
By their numbers in this assay, from the lowest: compounds 1, 2 and 3 (each within the scatter of the next).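

In this assay the bare phenyl of compound 3 supplies the reference point that the earlier pair lacked: removing the chloro gives no step beyond the scatter (a 1.0-fold higher number from compound 2 to compound 3 (0.01 log units; within the scatter)), and neither does removing the nitro (a 1.6-fold higher number from compound 1 to compound 3 (0.19 log units; within the scatter)). At this carbon of the six-membered aromatic ring, nitro, chloro and hydrogen therefore cannot be told apart on these numbers, and neither group can be credited with any contribution to cytotoxicity beyond what the unsubstituted phenyl already shows. Nothing at hand offers a reason for this result.

Whether an amine, a carboxylic acid or a methoxy group at this same carbon would give a step beyond the scatter remains open, as the three groups shown do not settle how far this insensitivity extends. Also open, on these data alone, is whether changes to the shared core, rather than to this carbon, would move the number, and whether the same picture would hold on cells other than the line used here.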